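The source may hold more compounds than are shown below. What is called first, only, known or untested is meant among the compounds shown, and "the series" means these compounds.

Measured so far in a functional assay on DU-145 cells (Homo sapiens) for inhibition, read by trypan blue exclusion, with a stated time of 96 h; a higher number here means a weaker inhibitor of growth, a lower number a stronger inhibitor of growth:
compound 1 `Cc1ccc(S/C(=C/c2ccc(Br)cc2)C(=O)c2ccc(Cl)cc2)cc1` gives 25000 nM
compound 2 `Cc1ccc(S/C(=C/c2ccc(Cl)cc2)C(=O)c2ccc(Cl)cc2)cc1` gives 10000 nM
compound 3 `O=C(/C(=C\c1cc(Cl)cc(Cl)c1Cl)Sc1ccccc1Br)c1ccc(Cl)cc1` gives 25000 nM

For the measured compounds named here, compound 3 stands level with compound 1 at the digits given, the two together at the high end of the three numbers in this assay; its only difference from compound 2 is a 2.5-fold lower number from compound 1 to compound 2 (0.40 log units; beyond the scatter) read across the series, with compound 2 the lower of the set.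

The step to compound 4 `Cc1ccc(S/C(=C/c2cc(Cl)cc(Cl)c2Cl)C(=O)c2ccc(Cl)cc2)cc1` is 4-methylphenyl in place of 2-bromophenyl on a sulfur. The remainder of compound 3 is kept unchanged. Going by the values given here, no measured pair covers this exchange: the one measured step, a 2.5-fold lower number from compound 1 to compound 2 (0.40 log units; beyond the scatter), concerns the halogen on a different ring and is modest in size. Among the compounds with values here, compounds 1 and 2 both carry the 4-methylphenyl on sulfur and sit at the high and middle of the range, so the entering group is not linked to any large shift in this assay, and there is no direct precedent for the leaving 2-bromophenyl.

With nothing in the measured steps pointing in either direction, the expectation for compound 4 in this assay is a step of no change at the digits printed from compound 3 to compound 4 (within the scatter), within the scatter. Compound 4 is estimated at 25000 nM, with a range from 10000 nM to 60000 nM.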

Compound 4, concentration for 50% growth inhibition: 50000 nM
Compound 4: the middle estimate sits 2.0-fold (0.30 log units) below what was measured; the measured number falls inside the stated range.
By their numbers in this assay, from the lowest: compound 2; then compounds 1, 3 and 4 (each within the scatter of the next).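

In this assay the step of a 2.0-fold higher number from compound 3 to compound 4 (0.30 log units; within the scatter) lies within the scatter, so this first reading at the sulfur does not separate 4-methylphenyl from 2-bromophenyl, at least with 2,3,5-trichlorophenyl on the double-bonded chain carbon. That carbon gives a split reading: 2,3,5-trichlorophenyl in place of 4-chlorophenyl is a 5.0-fold higher number from compound 2 to compound 4 (0.70 log units; beyond the scatter) and lies beyond the scatter, whereas 2,3,5-trichlorophenyl in place of 4-bromophenyl is a 2.0-fold higher number from compound 1 to compound 4 (0.30 log units; within the scatter) and stays within it, so the size of this exchange depends on which halophenyl it replaces. No supporting data bear on these steps, and their origin remains unexplained.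

As far as these compounds go, the sulfur comparison rests on a single pair, so it remains open whether the same indifference would hold with 4-chlorophenyl or 4-bromophenyl on the chain carbon. From the compounds shown here alone, it is equally open how this assay would respond to an amine or a carboxylic acid on the aromatic ring at the sulfur, since only a methyl and a bromine are represented there.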